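Restoring Hydrogen in Place of Chloro: Compound 4

The compounds below may be only part of what the source reports. "The series", "measured", "known", "first", "only" and "open" are said of these compounds alone.

Values measured in a functional assay on SK-BR-3 cells (Homo sapiens) for antiproliferative activity, read by luminescence, with a stated time of 72 h (on this read-out higher numbers stand for weaker inhibition and lower numbers for stronger inhibition), are these
- Compound 1 `CN1CC=C(c2c(O)cc(O)c3c(=O)cc(-c4ccc(Sc5nc6ccccc6[nH]5)cc4)oc23)CC1` gives (254 nM)
- Compound 2 `CN1CC=C(c2c(O)cc(O)c3c(=O)cc(-c4ccc(Sc5nc6ccccc6n5C)cc4Cl)oc23)CC1` gives (53.7 nM)
- Compound 3 `CN1CC=C(c2c(O)cc(O)c3c(=O)cc(-c4ccc(Sc5nc6ccccc6[nH]5)cc4Cl)oc23)CC1` gives (66.6 nM)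

Compound 3 stands level with compound 2 (53.7 nM) at the low end of these numbers, while compound 1 stands clearly higher (254 nM). Replacing methyl with hydrogen on the aromatic nitrogen is a step within the scatter (a 1.2-fold higher number from compound 2 to compound 3 (0.09 log units; within the scatter)).

Compound 4 `CN1CC=C(c2c(O)cc(O)c3c(=O)cc(-c4ccc(Sc5nc6ccccc6n5C)cc4)oc23)CC1` has not yet been measured. It departs from compound 2 by one change (hydrogen in place of chloro on an aromatic carbon), which is hydrogen in place of chloro on an aromatic carbon.

The measured step that bears most directly on this change is its reverse, chloro in place of hydrogen on an aromatic carbon. That step is modest but beyond the scatter (a 3.8-fold lower number from compound 1 to compound 3 (0.58 log units; beyond the scatter)). Within the data shown here, it was seen only in the pair carrying hydrogen on the aromatic nitrogen, and no measured pair tests it with the methyl group present. Read backwards, it still points to a higher number of similar size, meaning weaker inhibition.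

In this assay the expected change is therefore a rise (a 3.8-fold higher number from compound 2 to compound 4 (0.58 log units; beyond the scatter)). Compound 4 is expected at about 205 nM (estimated range 100 nM to 420 nM).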

Compound 4, half-maximal inhibitory concentration: 249 nM
Beside the measured number, compound 4's estimate is 1.2-fold (0.08 log units) below it; the measured number falls inside the stated range.
By their numbers in this assay, from the lowest: compounds 2 and 3 (each within the scatter of the next); then compounds 4 and 1 (each within the scatter of the next).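

In this assay, the chloro group on the aromatic carbon, ortho to a large group, now has a measured effect with the methyl group present on the aromatic nitrogen (a 4.6-fold higher number from compound 2 to compound 4 (0.67 log units; beyond the scatter)), so this change no longer rests only on the pair carrying hydrogen on that nitrogen. The size of the chloro step holds on both cores: the same change on two cores in this assay, a 3.8-fold lower number (0.58 log units; beyond the scatter) from compound 1 to compound 3 and a 4.6-fold lower number (0.67 log units; beyond the scatter) from compound 4 to compound 2, 1.2-fold (0.08 log units) apart, within the scatter of two such steps. Among these compounds, the change at the nitrogen, earlier seen only with chloro present, also stays within the scatter when hydrogen occupies the aromatic carbon (a 1.0-fold lower number from compound 1 to compound 4 (0.01 log units; within the scatter)), and the two readings of it agree: the same change on two cores in this assay, a 1.2-fold higher number (0.09 log units; within the scatter) from compound 2 to compound 3 and a 1.0-fold higher number (0.01 log units; within the scatter) from compound 4 to compound 1, 1.2-fold (0.08 log units) apart, within the scatter of two such steps.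

Among the compounds shown, only hydrogen and chloro occupy this aromatic carbon, so it remains open whether fluoro, bromo, methyl or methoxy there would give the same lower number as chloro. Only hydrogen and methyl occupy the aromatic nitrogen, which leaves open whether an ethyl group or a longer chain ending in an amine would also leave the number unmoved.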